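Cyclohexenyl in Place of Dimethoxyphenyl on the Amide

The source may report more compounds than this note shows. Statements on the series, on what has been measured and on what is new or still open speak of the compounds shown alone.

Compound 1 `O=C(Nc1cc(-c2ccccc2)nn1-c1ccccc1)c1ccccc1`: 4180 nM
Compound 2 `O=C(O)c1ccc(C(=O)Nc2cc(-c3ccccc3)nn2-c2ccccc2)cc1`: > 10000 nM (a limit)
Compound 3 `COc1cc(OC)cc(C(=O)Nc2cc(-c3ccccc3)nn2-c2ccccc2)c1`: > 10000 nM (a limit)

In an assay on HEK293 cells for displacement of a labelled ligand from metabotropic glutamate receptor 5 (Rattus norvegicus) (a lower number here means a stronger inhibitor, a higher number a weaker inhibitor), compound 1 gives 4180 nM. Compound 2 reaches only the assay limit of > 10000 nM. Compound 3 likewise reaches only the limit, > 10000 nM, so compound 3 stands at the weak end of the series, at the limit of > 10000 nM in this assay, at which 2 of the 3 values shown sit. Compound 4 `O=C(Nc1cc(-c2ccccc2)nn1-c1ccccc1)C1=CCCCC1` has not been measured; it differs from compound 3 by cyclohex-1-en-1-yl in place of 3,5-dimethoxyphenyl on a carbonyl carbon. Among the compounds with values here, two measured steps bear on this: an at least 2.3-fold higher number from compound 1 to compound 2 (0.37 log units; beyond the scatter) and an at least 2.3-fold higher number from compound 1 to compound 3 (0.37 log units; beyond the scatter), both toward weaker binding, while a step that the two limits leave unreadable from compound 2 to compound 3. Since leaving plain phenyl has so far weakened binding, a non-aromatic ring carrying no acceptors is expected to land nearer compound 1 than compound 3. Compound 4 is expected at 5000 nM, between 1500 nM and 20000 nM, an expected at least 2.0-fold lower number from compound 3 to compound 4 (0.30 log units; that floor lies within the scatter).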

Compound 4, inhibition constant: 4470 nM
Compound 4: the middle estimate sits 1.1-fold (0.05 log units) above what was measured, within the range that was stated.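

In this assay the ring on the carbonyl carbon need not be aromatic, since phenyl and cyclohex-1-en-1-yl cannot be told apart: the swap gives a 1.1-fold higher number from compound 1 to compound 4 (0.03 log units; within the scatter). Replacing the substituted rings with cyclohex-1-en-1-yl gives an at least 2.2-fold lower number from compound 3 to compound 4 (0.34 log units; beyond the scatter) and an at least 2.2-fold lower number from compound 2 to compound 4 (0.34 log units; beyond the scatter), so measurable binding returns. As far as these compounds go, the true size of both steps is unknown, as compound 2 and compound 3 each sit at a limit: the limit of > 10000 nM in this assay, at which 2 of the 4 values shown sit. The compounds shown leave open how a saturated cyclohexyl, a cyclopropyl or an open butyl chain would behave here. They also leave open whether any group at this position can bind more strongly than phenyl or cyclohex-1-en-1-yl.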